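A few compounds are considered here, and "the series" means these few. Any claim that something is new, unique, unknown or untested is made for them only; others in the source may bear on it.

Working notes on the series. Compound 1 `CC(C)=CCCC1=CC[C@H](C(=O)NO)[C@@H](c2ccccc2)C1` is the reference point of the set. In an assay on isolated protein for inhibition of Apoptosis regulator Bcl-2 (Homo sapiens), read by fluorescence polarization, with stated times of 5 min and 10 min (a higher number here means a weaker inhibitor, a lower number a stronger inhibitor), compound 1 gives 600 nM. Compound 2 `CC(C)=CCCC1=CC[C@@H](C(=O)N(C)C)[C@H](c2ccccc2)C1` belongs to the same series and differs from compound 1 at the amide-type nitrogen, among other things. In this assay compound 2 returns a limit of the assay, > 23000 nM, and not a number. Where compound 1 stands is therefore plain: its value is the only number in hand, and the one further value in hand is a limit, as the limit of > 23000 nM in this assay, at which 1 of the 2 values shown sits, records. Within the data shown here, no two measured compounds differ in a single place, so no measured step can be drawn from the pair.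

Compound 3 `CC(C)=CCCC1=CC[C@H](C(=O)N(C)O)[C@@H](c2ccccc2)C1` has not yet been measured. It differs from compound 1 by methyl in place of hydrogen on an amide-type nitrogen. Among the measured compounds shown here, with no measured step to lean on, the expectation rests on the two values alone: compound 1 with its number and compound 2 at its limit. The expected step in this assay is a 4.2-fold higher number from compound 1 to compound 3 (0.62 log units; beyond the scatter), toward weaker inhibition and beyond the usual scatter. Compound 3 is expected to give 2500 nM in this assay, within a range from 800 nM to 9000 nM.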

Compound 3, inhibition constant: 2100 nM
Compound 3: middle estimate off by 1.2-fold (0.08 log units), on the high side; the range from low to high includes it.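

Among these compounds, the first readable step at this position is now in hand: in this assay, methyl in place of hydrogen on the amide-type nitrogen gives a 3.5-fold higher number from compound 1 to compound 3 (0.54 log units; beyond the scatter), toward weaker inhibition. The other neighbours of that nitrogen, the carbonyl carbon and the oxygen, stay in place, and with the added methyl the series still returns a measured number, so the amide hydrogen of compound 1 can be replaced at a modest cost in this assay. Compound 2 remains a limit of the assay and not a number, and it differs from compound 3 in more than one place, so it supplies no step: the limit of > 23000 nM in this assay, at which 1 of the 3 values shown sits.

Still open, on these data alone, is whether the loss stays modest or grows with a longer chain on that nitrogen, such as ethyl or benzyl. Also open is what the hydroxy group on that nitrogen contributes on its own, as no pair shown isolates it and neither a methoxy group nor a simple hydrogen in its place appears among the compounds shown.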